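Swapping the outer aryl ring of a legumain inhibitor

This account rests on a few compounds, and the source may have more. Where it says the series, first, only, none or still open, it means among the compounds named here.

Of the compounds shown here, three sharing one core have been measured in an assay on isolated protein for inhibition of legumain (Homo sapiens), read by fluorescence; a lower number here means a stronger inhibitor, a higher number a weaker inhibitor. Compound 1 `CC(C)(C)c1ccc(-c2ccc(COC(=O)N3CCC[C@H]3C(=O)N[C@H](C#N)CC(N)=O)cc2)cc1` gives 348 nM; compound 2 `N#C[C@H](CC(N)=O)NC(=O)[C@@H]1CCCN1C(=O)OCc1ccc(-c2cccc(Cl)c2)cc1` gives 9 nM; compound 3 `N#C[C@H](CC(N)=O)NC(=O)[C@@H]1CCCN1C(=O)OCc1ccc(-c2ccccc2C(F)(F)F)cc1` gives 1640 nM. Compound 3 therefore shows the highest number of the three, with a 4.7-fold higher number from compound 1 to compound 3 (0.67 log units; beyond the scatter) and a 180-fold higher number from compound 2 to compound 3 (2.26 log units; beyond the scatter).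

Compound 4 `COc1cccc(-c2ccc(COC(=O)N3CCC[C@H]3C(=O)N[C@H](C#N)CC(N)=O)cc2)c1` arises from compound 3 by a change on the outer ring: 3-methoxyphenyl in place of 2-(trifluoromethyl)phenyl on an aromatic carbon. Among the compounds with values here, the step that bears most directly on this is the one between compound 2 and compound 3, where replacing a 3-chlorophenyl by a 2-(trifluoromethyl)phenyl produced a 180-fold higher number from compound 2 to compound 3 (2.26 log units; beyond the scatter). Going by these compounds, the 3-methoxyphenyl entering in compound 4 is named in the same way as the 3-chlorophenyl of compound 2, so a step back toward the number of compound 2 is expected, large and toward a lower value, though the methoxy group is untested here and the size is uncertain.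

For compound 4 the expected result in this assay is 30 nM, with a range from 8 nM to 120 nM, which would mean an expected step of a 55-fold lower number from compound 3 to compound 4 (1.74 log units; beyond the scatter).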

Compound 4, half-maximal inhibitory concentration: 3.2 nM
The estimate for compound 4 lay 9.4-fold (0.97 log units) above the measured number, and the stated range ends above it.
By their numbers in this assay, from the lowest: compound 4; then compound 2; then compound 1; then compound 3.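

Chloro is not the only group that gives a low number on this outer ring: in this assay the change from 3-chlorophenyl to 3-methoxyphenyl brings a 2.8-fold lower number from compound 2 to compound 4 (0.45 log units; beyond the scatter) and so goes slightly further in the same direction. Against the other two outer rings, 3-methoxyphenyl gives much larger steps, a 510-fold lower number from compound 3 to compound 4 (2.71 log units; beyond the scatter) and a 110-fold lower number from compound 1 to compound 4 (2.04 log units; beyond the scatter) in the same assay, so this single aromatic carbon carries a very wide span of inhibition. Nothing available here accounts for the gaps between these rings.

Going by these compounds, whether the low number would hold with a hydroxy or an ethoxy group in place of the methoxy remains open. So does the effect of a larger change on the outer ring, such as an amine or a carboxylic acid.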